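Compound 2 to compound 4: changing the aryl group

This account rests on a few compounds, and the source may have more. Where it says the series, first, only, none or still open, it means among the compounds named here.

Among the compounds with values here, in a functional assay on MKN-45 cells (Homo sapiens) for inhibition, read by CCK-8 assay, with a stated time of 24 h (on this read-out lower numbers stand for stronger inhibition and higher numbers for weaker inhibition), compound 1 (`Cc1ccccc1-n1cc(-c2ccc(/C=C3\C(=O)Nc4ccccc43)cc2)nn1`) gives 9770 nM as the only true number so far. Compound 2 (`O=C1Nc2ccccc2/C1=C/c1ccc(-c2cn(-c3ccccc3Cl)nn2)cc1`) gives > 20000 nM as a limit of the assay, not a number. Compound 3 (`N#Cc1ccc(-n2cc(-c3ccc(C=C4C(=O)Nc5ccccc54)cc3)nn2)cc1`) likewise gives > 20000 nM as a limit. The series therefore sits largely at one ceiling (the limit of > 20000 nM in this assay, at which 2 of the 3 values shown sit). Compound 4 (`O=C1Nc2ccccc2/C1=C/c1ccc(-c2cn(-c3ccc(Cl)c(C(F)(F)F)c3)nn2)cc1`) carries 4-chloro-3-(trifluoromethyl)phenyl in place of 2-chlorophenyl on an aromatic nitrogen. Within the data shown here, the only measured step on this group (an at least 2.0-fold higher number from compound 1 to compound 2 (0.31 log units; beyond the scatter)) is a smaller change, at least modest in size, and it ends at a limit. On that slim basis, a modest move to a lower number is expected (an at least 1.4-fold lower number from compound 2 to compound 4 (0.15 log units; that floor lies within the scatter)). For compound 4 the estimated value in this assay is 14000 nM (expected range 4000 nM to 40000 nM).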

Compound 4, half-maximal inhibitory concentration: 8890 nM
The estimate for compound 4 lay 1.6-fold (0.20 log units) above the measured number; the measured number falls inside the stated range.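

Within the data shown here, on the aryl group at the aromatic nitrogen, 4-chloro-3-(trifluoromethyl)phenyl in place of 2-chlorophenyl gives an at least 2.2-fold lower number from compound 2 to compound 4 (0.35 log units; beyond the scatter), the first step here that leaves the limit and ends at a true number. Replacing 2-methylphenyl with the same group gives a 1.1-fold lower number from compound 1 to compound 4 (0.04 log units; within the scatter), so this position accepts the group with more heavy atoms without a change beyond the scatter.

As far as these compounds go, compound 2 sits at a limit, so the full size of its step stays open. Also open, from the compounds shown here alone, is whether a chloro or trifluoromethyl group alone, or an amine at this ring, would give a lower number.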